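The compounds below may be only part of what the source reports. "The series", "measured", "known", "first", "only" and "open" are said of these compounds alone.

Of the compounds shown here, three sharing one core have been measured in a functional assay on CWR22R cells (Homo sapiens) for antiproliferative activity, read by fluorescence and propidium iodide staining, with a stated time of 96 h; on this read-out higher numbers stand for weaker inhibition and lower numbers for stronger inhibition. Compound 1 `O=C(Nc1ccc(S(F)(F)(F)(F)F)cc1)c1ccc(S(=O)(=O)c2ccc(O)cc2)cc1` gives 5780 nM. Compound 2 `O=C(Nc1cccc(S(F)(F)(F)(F)F)c1)c1ccc(S(=O)(=O)c2ccc(O)cc2)cc1` is built from the same atoms joined differently, and in this assay compound 2 gives 5660 nM; the difference between the core of compound 1 and the core of compound 2 is not broken down here, and the two values lie within the usual scatter of each other. Compound 3 `O=C(Nc1ccc(C(F)(F)F)cc1)c1ccc(S(=O)(=O)c2ccc(O)cc2)cc1` gives 16800 nM in this assay. From compound 1 to compound 3 the change is a group of 4 heavy atoms (1 carbon, 3 fluorine; no ring) in place of a group of 6 heavy atoms (5 fluorine, 1 sulfur; no ring), on an aromatic carbon, and it brought a 2.9-fold higher number from compound 1 to compound 3 (0.46 log units; beyond the scatter), a weakening of inhibition that lies beyond the scatter.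

Compound 4 `O=C(Nc1cccc(C(F)(F)F)c1)c1ccc(S(=O)(=O)c2ccc(O)cc2)cc1` has not yet been measured in this assay. It arises from compound 2 by a group of 4 heavy atoms (1 carbon, 3 fluorine; no ring) in place of a group of 6 heavy atoms (5 fluorine, 1 sulfur; no ring), on an aromatic carbon. Among the compounds with values here, this is the same kind of change as the one from compound 1 to compound 3, but the place is not identical: in compound 3 the trifluoromethyl stands para to a large group, whereas in compound 4 it stands meta to a large group. Within the data shown here, only one measured example of this change exists, so the expectation rests on that single step. The step from compound 2 to compound 4 is expected to be a 2.8-fold higher number from compound 2 to compound 4 (0.45 log units; beyond the scatter), because a 2.9-fold higher number from compound 1 to compound 3 (0.46 log units; beyond the scatter) was seen for the same kind of change at the other place. Compound 4 is therefore estimated at 16000 nM, with a range from 8000 nM to 35000 nM that allows for the different place and for the scatter of repeated measurements.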

Compound 4, half-maximal inhibitory concentration: 15100 nM
Estimate against measurement, compound 4: 1.1-fold (0.03 log units) above; measured number inside the range.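

In this assay, putting trifluoromethyl on the aromatic carbon in place of the group of five fluorines on sulfur brought a 2.7-fold higher number from compound 2 to compound 4 (0.43 log units; beyond the scatter), a weakening of inhibition. Set beside the earlier example, the same replacement behaved in much the same way on the two cores, and the gap between the two steps gives no sign that the core changed its size: the same change on two cores in this assay, a 2.9-fold higher number (0.46 log units; beyond the scatter) from compound 1 to compound 3 and a 2.7-fold higher number (0.43 log units; beyond the scatter) from compound 2 to compound 4, 1.1-fold (0.04 log units) apart, within the scatter of two such steps

Within this small set, then, the step measured on one core was a fair guide to the step on the other, but two pairs are a narrow base, so nothing shows that it would hold on a third core or for a different replacement, and nothing here explains why the group that enters gives the weaker inhibition.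

The compounds shown leave open how other groups on this aromatic carbon would compare with these two, for example a nitrile, an amine or a carboxylic acid. They also leave open whether the step would keep its size if the hydroxyl group elsewhere in the molecule gave way to a methoxy group.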